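This account rests on a few compounds, and the source may have more. Where it says the series, first, only, none or still open, it means among the compounds named here.

Measured compounds:
Compound 1 `N=C(S)CCn1ncccc1=O`: in a functional assay on the whole organism (stomach) for inhibition, with Rattus norvegicus as the target, at a dose of 100 mg/kg by the intraduodenal route (a higher number here means more inhibition at the dose given (going by the name of the read-out), a lower number less inhibition), compound 1 gives 28.8%.
Compound 2 `C/N=C(\S)CCn1ncccc1=O`: in this assay compound 2 gives 35.7%.

Compound 1 stands with compound 2 on the numbers shown; the step of a number 6.9 percentage points higher from compound 1 to compound 2 (within the scatter) lies within the scatter, so the two readings cannot be told apart. That step concerns only the group at the end of the saturated chain.

Compound 3 `N=C(S)CCn1nc(-c2ccccc2)ccc1=O` is yet to be measured. It differs from compound 1 by phenyl in place of hydrogen on an aromatic carbon. Within the data shown here, the one measured step changes the chain end and leaves the aromatic ring untouched, so it does not bear on a change made on the ring. Among the measured compounds shown here, no measured pair shows what this change does in this assay, and there is therefore no basis to expect a step beyond the scatter in either direction; the expected step of a number 1.2 percentage points higher from compound 1 to compound 3 (within the scatter) is one of no change, with wide uncertainty. For compound 3 the estimated inhibition in this assay is 30%, within a range from 8% to 55%.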

Compound 3, a percentage reported as inhibition, in the whole organism at one dose (the size of the read-out at that dose, not a potency): 53.7%
The estimate for compound 3 lay 23.7 percentage points below the measured number; the range from low to high includes it.
By their numbers in this assay, from the lowest: compounds 1 and 2 (each within the scatter of the next); then compound 3.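

Among these compounds, with phenyl in place of hydrogen on this aromatic carbon, next to the ring nitrogen, this assay shows a number 24.9 percentage points higher from compound 1 to compound 3 (beyond the scatter), and this is the first step to go beyond the scatter, since the chain-end change gave only a number 6.9 percentage points higher from compound 1 to compound 2 (within the scatter). The ring of the shared core, left untouched by that earlier change, is therefore a place where a substitution can shift this inhibition upward, and a group as large as phenyl is accepted there, although this is a reading at one dose and not a potency. Nothing available accounts for the rise.

One pair cannot show whether the gain belongs to phenyl itself or would also come with a methyl, a chlorine or a cyclohexyl on the same carbon. From the compounds shown here alone, it also remains open whether phenyl on this carbon would give a similar step with the methyl group on the chain-end nitrogen of compound 2, or whether a phenyl bearing a methoxy group or a carboxylic acid would keep the gain.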